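Methyl on the sulfamoyl nitrogen of compound 3

This account rests on a few compounds, and the source may have more. Where it says the series, first, only, none or still open, it means among the compounds named here.

Compound 3 `CCN1CCCC1CNC(=O)c1cc(NS(N)(=O)=O)c(Cl)cc1OC` carries a sulfamoylamino group on the shared core. In a functional assay on the whole organism for inhibition, with Mus musculus as the target (a higher number here means that more compound is needed for the effect, a lower number that less compound is needed), compound 3 gives only a limit, > 50 mg/kg. Compound 2 `CCN1CCCC1CNC(=O)c1cc(NS(=O)(=O)NC)c(Cl)cc1OC`, the (methylsulfamoyl)amino analogue, likewise reaches only a limit; in this assay compound 2 gives > 50 mg/kg. For the measured compounds named here, compound 1 `CCN1CCCC1CNC(=O)c1cc(N(C)S(C)(=O)=O)c(Cl)cc1OC`, bearing methyl(methylsulfonyl)amino, is the one member with a number: in this assay compound 1 gives 7.7 mg/kg.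

Compound 4 `CCN1CCCC1CNC(=O)c1cc(N(C)S(N)(=O)=O)c(Cl)cc1OC` differs from compound 3 by methyl in place of hydrogen on a sulfonamide nitrogen. Going by the values given here, the steps that bear on this change are an at least 6.4-fold higher number from compound 1 to compound 3 (0.81 log units; beyond the scatter) and an at least 6.4-fold higher number from compound 1 to compound 2 (0.81 log units; beyond the scatter), both running away from the methylated aryl nitrogen of compound 1. Compound 4 restores that methyl on the nitrogen bound to the aromatic carbon, so it recovers part of what separates compound 3 from compound 1. The step that the two limits leave unreadable from compound 2 to compound 3 gives no size because two of the three values sit at the limit of > 50 mg/kg in this assay, at which 2 of the 3 values shown sit.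

The expectation is therefore a move back toward the number of compound 1, though of uncertain size: the step of an at least 1.6-fold lower number from compound 3 to compound 4 (0.22 log units; that floor lies within the scatter) is an estimate, not a reading. For compound 4 the expected value in this assay is 30 mg/kg, with a range from 8 mg/kg to 100 mg/kg, and a real chance that only a limit is reported.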

Compound 4, dose for half-maximal effect: > 50 mg/kg
Compound 4 ended at the assay's limit (the forecaster's own chance of this, stated with the estimate: 45%); at least 1.6-fold (0.22 log units) between middle value and limit.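

Methyl on the sulfonamide nitrogen does not bring back a measurable dose on its own: in this assay, with that methyl kept, amino in place of methyl on a sulfonyl sulfur gives an at least 6.4-fold higher number from compound 1 to compound 4 (0.81 log units; beyond the scatter). For the compounds shown here, this is the first step that isolates the group on the sulfonyl sulfur, and of the four compounds only compound 1, the one with methyl there, gives a number rather than a limit. The steps from compound 3 to compound 4 and from compound 2 to compound 4 cannot be read, so any effect of the nitrogen methyl with amino on the sulfur stays hidden because these compounds sit at the same limit: the limit of > 50 mg/kg in this assay, at which 3 of the 4 values shown sit.

Going by these compounds, how compound 2, compound 3 and compound 4 rank beyond that limit remains unknown, and compound 1 has no partner with hydrogen on the sulfonamide nitrogen and methyl on the sulfur, so the contribution of its nitrogen methyl is also unresolved. Also open, on these data alone, is whether ethyl or dimethylamino on the sulfonyl sulfur would give a number, and so how narrowly the methyl requirement holds.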